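Benzyl ring substituent change on the shared core

The source may hold more compounds than are shown below. What is called first, only, known or untested is meant among the compounds shown, and "the series" means these compounds.

Measured compounds:
compound 1 `CCNC(=O)N1CCN(C(=S)SCc2cn(Cc3ccccc3F)nn2)CC1`; in a functional assay on MGC-803 cells (Homo sapiens) for cytotoxicity, read by MTT assay, with a stated time of 72 h (on this read-out higher numbers stand for weaker inhibition and lower numbers for stronger inhibition), compound 1 gives 2830 nM.
compound 2 `CCNC(=O)N1CCN(C(=S)SCc2cn(Cc3ccc(C)cc3)nn2)CC1`; in this assay compound 2 gives 19800 nM.

Compound 2 stands at the highest number of the two measured in this assay; its nearest neighbour is compound 1, with a 7.0-fold higher number from compound 1 to compound 2 (0.84 log units; beyond the scatter). Compound 3 `CCNC(=O)N1CCN(C(=S)SCc2cn(Cc3ccc(OC)cc3)nn2)CC1` is not yet measured. It differs from compound 2 by methoxy in place of methyl on an aromatic carbon. Among the measured compounds shown here, no measured step changes methyl to methoxy, so nothing bears on it directly. For the measured compounds named here, the only measured step, a 7.0-fold higher number from compound 1 to compound 2 (0.84 log units; beyond the scatter), swaps the whole substitution pattern of the benzyl ring at once and says little about a single-group exchange. Going by the values given here, with no step bearing on it, the expectation for this assay is a step within the scatter, in no clear direction; a somewhat lower number is given slightly more weight, but this is weakly held. Compound 3 is therefore expected to give about 15000 nM in this assay, in the range from 5000 nM to 50000 nM, which means an expected step of a 1.3-fold lower number from compound 2 to compound 3 (0.12 log units; within the scatter).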

Compound 3, half-maximal inhibitory concentration: > 128000 nM
Compound 3 ended at the assay's limit; the forecaster's own chance of this, stated with the estimate: 10%; middle value at least 8.5-fold (0.93 log units) away from the limit.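

Compound 3 stands at a limit of this assay, not at a number: the limit of > 128000 nM in this assay, at which 1 of the 3 values shown sits.

From the compounds shown here alone, the exchange of one group at the same ring position, 4-methylbenzyl to 4-methoxybenzyl, is enough to move the read-out, with an at least 6.4-fold higher number from compound 2 to compound 3 (0.81 log units; beyond the scatter), and the true size of this step stays unknown beyond that bound. The earlier step changed the whole substitution pattern of the benzyl ring at once, so it could not show that this single position responds so sharply to methoxy in place of methyl. Against the 2-fluorophenyl group the change is wider still, with an at least 45-fold higher number from compound 1 to compound 3 (1.65 log units; beyond the scatter), and both compounds carrying a group para to a large group give higher numbers than compound 1, with none of the three going against this.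

These steps cannot separate the effect of where the ring carries its group from the effect of which group it carries, and they give no cause for the loss. An unsubstituted benzyl group, or an amine or a carboxylic acid on the ring, would be needed to show how far this trend extends across the series.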